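Trimming the aryl group on a thiazole hydrazone series

This account rests on a few compounds, and the source may have more. Where it says the series, first, only, none or still open, it means among the compounds named here.

Compound 1 `C/C(=N\Nc1nc(-c2ccc(Cl)cc2)cs1)c1cc2ccccc2o1`: 26600 nM
Compound 2 `C/C(=N\Nc1nc(-c2ccc(C)cc2)cs1)c1cc2ccccc2o1`: 14300 nM
Compound 3 `C/C(=N\Nc1nc(-c2cc3ccccc3o2)cs1)c1cc2ccccc2o1`: 24100 nM

In a functional assay on HeLa cells (Homo sapiens) for antiproliferative activity (a lower number here means a stronger inhibitor, a higher number a weaker inhibitor), the three compounds sit close together: the steps of a 1.9-fold lower number from compound 1 to compound 2 (0.27 log units; within the scatter) and a 1.7-fold higher number from compound 2 to compound 3 (0.23 log units; within the scatter) are both within the scatter, so compound 2 cannot be called the strongest, even though its number is the lowest of the three. Compound 4 `C/C(=N\Nc1nc(C)cs1)c1cc2ccccc2o1` differs from compound 2 by methyl in place of 4-methylphenyl on an aromatic carbon. Going by the values given here, none of the measured steps removes the aryl group entirely; they only swap one aryl for another, and each stayed within the scatter. That leaves the expectation open. A weaker inhibitor is thought more likely once the ring is gone, so compound 4 is expected to give 35000 nM, in a range from 12000 nM to 100000 nM, a step of a 2.4-fold higher number from compound 2 to compound 4 (0.39 log units; beyond the scatter).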

Compound 4, half-maximal inhibitory concentration: 8970 nM
Compound 4: the middle estimate sits 3.9-fold (0.59 log units) above what was measured; the measured number lies below the stated range.
By their numbers in this assay, from the lowest: compounds 4, 2, 3 and 1 (each within the scatter of the next, the first and the last beyond it).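

In this assay, the aromatic ring on this carbon next to the ring nitrogen proves dispensable, as methyl in place of 4-methylphenyl gives a 1.6-fold lower number from compound 2 to compound 4 (0.20 log units; within the scatter). Against the two other aryl groups the methyl goes beyond the scatter, modestly, with a 2.7-fold lower number from compound 3 to compound 4 (0.43 log units; beyond the scatter) and a 3.0-fold lower number from compound 1 to compound 4 (0.47 log units; beyond the scatter), so an aryl group at this position brings no gain in this set. Nothing available accounts for this result.

On these data alone, whether a hydrogen, an ethyl group or an amine on this carbon would hold the number stays open. So does whether a carboxylic acid here would be tolerated.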